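From 6-methylpyridin-3-yl to 2-chloropyridin-3-yl

The source may hold more compounds than are shown below. What is called first, only, known or untested is meant among the compounds shown, and "the series" means these compounds.

Within the data shown here, in an ADME assay on HEK-293T cells (Homo sapiens) for cytotoxicity, read by MTT assay, with a stated time of 48 h (on this read-out higher numbers stand for lower toxicity in this test and lower numbers for higher toxicity in this test), compound 2 `Cc1ccc(C(=O)N2N=C(c3ccccc3)CC2c2cn(C)c3ccccc23)cn1` gives 154000 nM, the only true number so far. Compound 1 `Cn1cc(C2CC(c3ccccc3)=NN2C(=O)c2ccc(Cl)nc2)c2ccccc21` reaches only a limit of the test, > 300000 nM. Among the measured compounds shown here, the one measured step, an at least 1.9-fold lower number from compound 1 to compound 2 (0.28 log units; that floor lies within the scatter), puts methyl in place of chloro on an aromatic carbon and is all that bears on the next change. Compound 3 `Cn1cc(C2CC(c3ccccc3)=NN2C(=O)c2cccnc2Cl)c2ccccc21` differs from compound 2 as follows: 2-chloropyridin-3-yl in place of 6-methylpyridin-3-yl on a carbonyl carbon. For the measured compounds named here, with only that small step as a guide, no change beyond the scatter is expected in this assay. The expected change is a 1.3-fold higher number from compound 2 to compound 3 (0.11 log units; within the scatter). For compound 3, the estimate is 200000 nM, with an expected range from 100000 nM to 300000 nM.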

Compound 3, half-maximal cytotoxic concentration: > 300000 nM
Compound 3: only a limit was reported (the forecaster's own chance of this, stated with the estimate: 40%); at least 1.5-fold (0.17 log units) between middle value and limit.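

In this assay, putting 2-chloropyridin-3-yl in place of 6-methylpyridin-3-yl on the carbonyl carbon gives an at least 1.9-fold higher number from compound 2 to compound 3 (0.28 log units; that floor lies within the scatter), so this change cannot be shown to exceed the scatter. Compound 3 reaches a limit of the test rather than a true number, as compound 1 does, so the step between those two cannot be read: the limit of > 300000 nM in this assay, at which 2 of the 3 values shown sit.

On these data alone, how far past that limit compound 1 and compound 3 lie stays open. Also open, as far as these compounds go, is whether an amine or a carboxylic acid in place of the chloro group would give a number clearly apart from that of compound 2.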